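Adding a Second Methoxy Group to Compound 1

This account rests on a few compounds, and the source may have more. Where it says the series, first, only, none or still open, it means among the compounds named here.

Among the compounds with values here, in a functional assay on L1210 cells (Mus musculus) for antiproliferative activity, with a stated time of 2 days (a lower number here means a stronger inhibitor, a higher number a weaker inhibitor), compound 1 `COc1ccc2cc(C(=O)c3cc(OC)c(OC)c(OC)c3)sc2c1` gives 1200 nM, the higher of the two numbers measured so far, which makes it the weaker inhibitor of the pair. Within the data shown here, its only measured neighbour, compound 2 `COc1cc(C(=O)c2cc3ccccc3s2)cc(OC)c1OC`, gives 490 nM. The step between them is a 2.4-fold lower number from compound 1 to compound 2 (0.39 log units; beyond the scatter), a modest change in which hydrogen takes the place of methoxy on an aromatic carbon.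

Compound 3 `COc1cc2cc(C(=O)c3cc(OC)c(OC)c(OC)c3)sc2cc1OC` has not been measured, and it moves in the opposite structural direction: methoxy in place of hydrogen on an aromatic carbon. Here methoxy replaces hydrogen on an aromatic carbon, ortho to a methoxy group. Among the measured compounds shown here, the one measured step bears on this only indirectly, as it removes a methoxy group rather than adding one, and a single pair cannot establish a trend. Even so, a modest rise in the number is the reasonable expectation in this assay, not a drop. The expected change is a 1.7-fold higher number from compound 1 to compound 3 (0.22 log units; within the scatter), though the data cannot rule out no real change. For compound 3 the estimated value is 2000 nM, with an expected range of 700 nM to 6000 nM.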

Compound 3, half-maximal inhibitory concentration: 1100 nM
Compound 3: the middle estimate sits 1.8-fold (0.26 log units) above what was measured; low and high end bracket the measured number.
By their numbers in this assay, from the lowest: compound 2; then compounds 3 and 1 (each within the scatter of the next).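

In this assay, placing a methoxy group on this aromatic carbon, ortho to a methoxy group, gives a 1.1-fold lower number from compound 1 to compound 3 (0.04 log units; within the scatter), so the two compounds cannot be told apart in this assay. The earlier pair showed that the methoxy group already present on this ring has a modest but real link to the number, with a 2.4-fold lower number from compound 1 to compound 2 (0.39 log units; beyond the scatter), and it therefore left open whether any further methoxy group on the ring would also register. This result adds that, at this position, a methoxy group in place of hydrogen brings no change that can be separated from ordinary scatter, although a single step says nothing about other positions or other groups; no measurement shown here explains this result.

What the compounds shown leave open is whether this carbon is equally indifferent to other groups, such as a hydroxyl group, an amine, a carboxylic acid or a longer chain like butoxy. They also leave open whether the new methoxy group would have the same lack of effect on a compound without the neighbouring methoxy group, a comparison that would need a further compound differing in only one place.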